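The source may report more compounds than this note shows. Statements on the series, on what has been measured and on what is new or still open speak of the compounds shown alone.

Measured compounds in a functional assay on MIA PaCa-2 cells (Homo sapiens) for inhibition; a higher number here means a weaker inhibitor, a lower number a stronger inhibitor:

compound 1 `CCC(C)C1NC(=O)N(C2CCCCC2)C1=O`: compound 1 gives only a limit, > 100000 nM.
compound 2 `CC(C)C(NC(=O)NO)C(=O)NC1CCCC1`: compound 2 gives only a limit, > 100000 nM.
compound 3 `CC(C)C1NC(=O)N(C2CCCCC2)C1=O`: compound 3 gives only a limit, > 100000 nM.

All three values sit at the same limit (the limit of > 100000 nM in this assay, at which 3 of the 3 values shown sit), so no number is known for any of them. The change from compound 3 to compound 1, (methyl in place of hydrogen on a saturated chain carbon, two bonds along the chain from a saturated ring carbon), gives a step that the two limits leave unreadable from compound 3 to compound 1, which the two limits leave unreadable.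

The difference between the core of compound 2 and the core of compound 3 is not broken down here. Compound 4 `CCC(C)C(NC(=O)NO)C(=O)NC1CCCC1` carries the same kind of change relative to compound 2, (methyl in place of hydrogen on a saturated chain carbon, three bonds along the chain from an amide-type nitrogen and a carbonyl carbon). The surroundings differ: in compound 1 the methyl enters two bonds along the chain from a saturated ring carbon, whereas in compound 4 it enters three bonds along the chain from an amide-type nitrogen and a carbonyl carbon.

The step from compound 2 to compound 4 in this assay is expected to be a step that the limit leaves unreadable from compound 2 to compound 4, the same kind of change having shown nothing readable before. Compound 4 is therefore expected to give 150000 nM, most likely again only a limit, with a range from 40000 nM to 600000 nM.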

Compound 4, half-maximal inhibitory concentration: > 100000 nM
Compound 4 gave a limit, no number; the forecaster's own chance of this, stated with the estimate: 80%; the middle value lies beyond the limit too.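

Compound 2 and compound 4 both give only a limit, so no new step can be read between them, and the series stays at a single limit: the limit of > 100000 nM in this assay, at which 4 of the 4 values shown sit.

The compounds shown leave open how large the change from hydrogen to methyl is on either core, and whether either core can give a number in this assay.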